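The compounds below may be only part of what the source reports. "The series", "measured", "known", "first", "only" and "open" are said of these compounds alone.

Three compounds share one core and differ only in the group that hangs from the nitrogen. Compound 1 `COc1ccc(Nc2nc(-c3cccc(F)c3)nc3ccc(F)cc23)cc1` carries a 4-methoxyphenyl there, compound 2 `Fc1cccc(Nc2nc(-c3cccc(F)c3)nc3ccc(F)cc23)c1` a 3-fluorophenyl, and compound 3 `Fc1cccc(-c2nc(Nc3cccc(Br)c3)c3cc(F)ccc3n2)c1` a 3-bromophenyl. In a functional assay on U-937 cells (Homo sapiens) for cytotoxicity, read by MTT assay, with a stated time of 48 h (a lower number here means a stronger inhibitor, a higher number a weaker inhibitor), compound 1 gives 41100 nM. In this assay compound 2 gives 42300 nM. For compound 3 this assay reports only a limit, > 50000 nM, and not a number. Compound 3 thus stands at the edge of what this assay reports, namely (the limit of > 50000 nM in this assay, at which 1 of the 3 values shown sits); its two neighbours have numbers and it has none.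

Compound 4 `Cc1cccc(Nc2nc(-c3cccc(F)c3)nc3ccc(F)cc23)c1` is the next step: methyl in place of bromo on an aromatic carbon. Of the steps measured so far, a 1.0-fold higher number from compound 1 to compound 2 (0.01 log units; within the scatter) and an at least 1.2-fold higher number from compound 1 to compound 3 (0.08 log units; that floor lies within the scatter), and most directly an at least 1.1-fold higher number from compound 2 to compound 3 (0.07 log units; that floor lies within the scatter). None of these reaches beyond the scatter; changing one small group on this phenyl ring has not moved the numbers in any of the three cases seen. Compound 4 is thus expected to show a number no higher from compound 3 to compound 4 (the limit leaves the size open). Compound 4 is estimated at 50000 nM, with a range from 25000 nM to 100000 nM, and with a fair chance that this assay again reports only a limit rather than a number.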

Compound 4, half-maximal inhibitory concentration: > 50000 nM
Compound 4: a limit, no number (the forecaster's own chance of this, stated with the estimate: 50%); the middle value lies on the limit itself.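

Replacing bromo with methyl gives a second compound for which this assay reports only a limit, so the steps that depend on both limits cannot be read, and two different small groups on this phenyl ring now end at the same edge: the limit of > 50000 nM in this assay, at which 2 of the 4 values shown sit.

Set against the two compounds that have numbers, the change reads as an at least 1.1-fold higher number from compound 2 to compound 4 (0.07 log units; that floor lies within the scatter), and as an at least 1.2-fold higher number from compound 1 to compound 4 (0.08 log units; that floor lies within the scatter). Neither floor shows a real difference, so methyl, a carbon group rather than a halogen, joins the small groups on this ring that give no step beyond the scatter.

The compounds shown leave open whether a different kind of group at this place, such as an amine, a carboxylic acid or a longer chain like propyl, would give a clearly lower number in this assay. They also leave open how far apart compound 3 and compound 4 really lie, and whether a change elsewhere on the shared core would move the number more than changes on this ring have.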